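The compounds below may be only part of what the source reports. "The series", "measured", "known", "first", "only" and "open" are said of these compounds alone.

Compounds measured in a functional assay on A549 cells (Homo sapiens) for cytotoxicity, read by XTT assay, with a stated time of 72 h; a higher number here means a weaker inhibitor, a lower number a stronger inhibitor:
compound 1 `COc1cc(/C(=N/NC(C)=O)c2ccc3c(ccn3C)c2)cc(OC)c1OC` gives > 10000 nM.
compound 2 `CN/N=C(/c1cc(OC)c(OC)c(OC)c1)c1ccc2c(ccn2C)c1` gives > 1000 nM.

The figure of compound 2 is a limit of the assay, (the limit of > 1000 nM in this assay, at which 1 of the 2 values shown sits). The figure of compound 1 is likewise a limit, (the limit of > 10000 nM in this assay, at which 1 of the 2 values shown sits). Among the measured compounds shown here, the single measured step, a step that the two limits leave unreadable from compound 1 to compound 2, is therefore unreadable in size and direction: both values sit at limits and neither is a number. Compound 2 thus stands only as a limit, with no numerical position in this assay.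

Compound 3 `COc1cc(/C(=N/C(=O)OC(C)(C)C)c2ccc3c(ccn3C)c2)cc(OC)c1OC` differs from compound 2 by tert-butoxycarbonyl in place of methylamino on a double-bonded nitrogen. For the measured compounds named here, no measured step bears on this change, and the step between compound 1 and compound 2 gives no size to carry over. The expectation is accordingly anchored only at the limits shown.

Compound 3 is expected to remain weak in this assay, with an estimate of 8000 nM and a range of 1000 nM to 50000 nM. This estimate implies a step that the limit leaves unreadable from compound 2 to compound 3, expected not to exceed the scatter in any readable way.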

Compound 3, half-maximal inhibitory concentration: > 10000 nM
Compound 3 gave a limit, no number (the forecaster's own chance of this, stated with the estimate: 60%); middle value at least 1.2-fold (0.09 log units) away from the limit.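

In this assay compound 3 gives > 10000 nM, which is a limit and not a number. Among the compounds shown here, no step among compound 1, compound 2 and compound 3 can be read. The compounds shown leave open whether any group on the double-bonded nitrogen gives a measurable value.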